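A Furan-2-yl Swap in a Series with Low Inhibition Numbers

A few compounds are considered here, and "the series" means these few. Any claim that something is new, unique, unknown or untested is made for them only; others in the source may bear on it.

Compound 1: `O=C(O)CCC1=C(c2ccc(Cl)cc2)NC(=S)NC1c1ccccc1O` – 1.22%
Compound 2: `O=C(O)CCC1=C(c2ccccc2)NC(=S)NC1c1ccccc1O` – 12.9%

Of the compounds shown here, two have been measured in a functional assay on the whole organism (strain Albino) for inhibition, with Rattus norvegicus as the target, with stated times of 1 h and 3 h, at a dose of 20 mg/kg by the oral route; on this read-out higher numbers stand for more inhibition at the one dose given (going by the name of the read-out) and lower numbers for less inhibition. Compound 1 `O=C(O)CCC1=C(c2ccc(Cl)cc2)NC(=S)NC1c1ccccc1O` gives 1.22%, the lowest of the two numbers; its nearest neighbour, compound 2 `O=C(O)CCC1=C(c2ccccc2)NC(=S)NC1c1ccccc1O`, gives 12.9%. Among the measured compounds shown here, the single measured step, a number 11.7 percentage points higher from compound 1 to compound 2 (beyond the scatter), is modest but beyond the scatter.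

Compound 3 `O=C(O)CCC1=C(c2ccc(Cl)cc2)NC(=S)NC1c1ccco1` has not been measured. It differs from compound 1 in one place: furan-2-yl in place of 2-hydroxyphenyl on a saturated ring carbon. For the measured compounds named here, no measured step touches this place: the only known step, from compound 1 to compound 2, alters the 4-chlorophenyl group, which compound 3 keeps unchanged. The move to a furan-2-yl group is therefore uncharted, and its direction cannot be read from the two numbers in hand. Because compound 1 gives 1.22%, the expectation for compound 3 stays close to that number, and a modest rise is about as plausible as no change. The step expected is a number 4.8 percentage points higher from compound 1 to compound 3 (within the scatter), within the scatter. Compound 3 is estimated at 6%, with a range from 0% to 20%.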

Compound 3, a percentage reported as inhibition, in the whole organism at one dose (the size of the read-out at that dose, not a potency): 5.52%
Compound 3: the middle estimate sits 0.5 percentage points above what was measured, within the range that was stated.
By their numbers in this assay, from the lowest: compounds 1, 3 and 2 (each within the scatter of the next, the first and the last beyond it).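

Among the compounds shown here, compound 3 is the first compound here to change the group on the saturated ring carbon, and in this assay the swap gives a number 4.3 percentage points higher from compound 1 to compound 3 (within the scatter). With the 4-chlorophenyl group kept, 2-hydroxyphenyl, with 1 hydrogen-bond donor, can therefore give way to the smaller furan-2-yl, with 0 hydrogen-bond donors, without a difference that can be told apart from the usual scatter, so this hydroxyl-bearing ring shows no measurable need at this place in this pair, though both numbers are low and leave little room to see a loss. No measured information on the compounds explains this result.

On these data alone, it remains open whether furan-2-yl would behave the same way on the core of compound 2, which carries a plain phenyl group and gives 12.9%. As far as these compounds go, it also remains open how this position would respond to a quite different group, such as a methyl group or a ring bearing an amine, since the two groups compared here are both small aromatic rings.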